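A few compounds are considered here, and "the series" means these few. Any claim that something is new, unique, unknown or untested is made for them only; others in the source may bear on it.

Measured compounds and values:
Compound 1 `CN1CCN(CCCCCCn2c3c(c4ccccc42)C(=O)c2c[n+]([O-])c4ccccc4c2C3=O)CC1`, in a functional assay on HCT-116 cells (Homo sapiens) for cytotoxicity, read by MTT assay, with a stated time of 72 h; on this read-out lower numbers stand for stronger inhibition and higher numbers for weaker inhibition: 2900 nM
Compound 2 `CN1CCN(CCCCCn2c3c(c4ccccc42)C(=O)c2c[n+]([O-])c4ccccc4c2C3=O)CC1`, in this assay: 1220 nM
Compound 3 `O=C1c2c[n+]([O-])c3ccccc3c2C(=O)c2c1c1ccccc1n2Cc1cn([C@@H]2C[C@H](O)[C@@H](CO)O2)nn1`, in this assay: 50 nM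

Compound 1 gives the highest number of the three, so on this read-out it is the weakest of the set. Among the measured compounds shown here, the single measured step from it, a 2.4-fold lower number from compound 1 to compound 2 (0.38 log units; beyond the scatter), shows only a modest change when the chain that carries the 4-methylpiperazin-1-yl group is shortened. Compound 4 `O=C1c2c[n+]([O-])c3ccccc3c2C(=O)c2c1c1ccccc1n2Cc1cn(C[C@H](O)CO)nn1` is not yet measured. It differs from compound 1 by a much larger change: 1-(2,3-dihydroxypropyl)-1H-1,2,3-triazol-4-yl in place of 5-(4-methylpiperazin-1-yl)pentyl on a saturated chain carbon bound to an aromatic nitrogen. For the measured compounds named here, no measured step follows this exact change, so the one step recorded bears on it only indirectly. What does bear on it is compound 3, which also carries a 1H-1,2,3-triazol-4-yl group on a saturated chain carbon bound to an aromatic nitrogen and gives 50 nM in this assay. Compound 4 is therefore expected to lie far below compound 1, with a 19-fold lower number from compound 1 to compound 4 (1.29 log units; beyond the scatter), and its estimated value is 150 nM, in a range from 40 nM to 700 nM.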

Compound 4, half-maximal inhibitory concentration: 400 nM
Compound 4: middle estimate off by 2.7-fold (0.43 log units), on the low side, and the stated range covers the measured number.
By their numbers in this assay, from the lowest: compound 3; then compound 4; then compound 2; then compound 1.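

In this assay, 1-(2,3-dihydroxypropyl)-1H-1,2,3-triazol-4-yl in place of the 4-methylpiperazin-1-yl chains on a saturated chain carbon bound to an aromatic nitrogen gives a 7.3-fold lower number from compound 1 to compound 4 (0.86 log units; beyond the scatter) and a 3.1-fold lower number from compound 2 to compound 4 (0.48 log units; beyond the scatter), so this position tolerates a side chain of a quite different kind, and both steps exceed the one seen on shortening the chain. The 1H-1,2,3-triazol-4-yl group alone does not set the value, since 2,3-dihydroxypropyl in place of 4-hydroxy-5-(hydroxymethyl)oxolan-2-yl on an aromatic nitrogen gives an 8.0-fold higher number from compound 3 to compound 4 (0.90 log units; beyond the scatter). No supporting measurement explains either change.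

The compounds shown leave open how the 1H-1,2,3-triazol-4-yl group would fare with a 4-methylpiperazin-1-yl chain on its ring nitrogen. They also leave open how the opposite configuration of the 2,3-dihydroxypropyl stereocentre, or a plain 2-hydroxyethyl group, would compare.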